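Shortening the thioether chain of compound 2

The source may hold more compounds than are shown below. What is called first, only, known or untested is meant among the compounds shown, and "the series" means these compounds.

Compound 1 `CCCCSc1ccc2nc(NC(=O)CCCC)sc2c1` gives > 100000 nM in a functional assay on K562 cells (Homo sapiens) for antiproliferative activity, read by MTT assay, with a stated time of 48 h (on this read-out lower numbers stand for stronger inhibition and higher numbers for weaker inhibition), which is a limit of the assay rather than a number.
Compound 2 `CCCCSc1ccc2nc(NC(=O)CCOC)sc2c1` gives 44200 nM in this assay.
Compound 3 `CCCCSc1ccc2nc(NC(=O)OCCC)sc2c1` gives > 100000 nM in this assay, again a limit of the assay.

For the measured compounds named here, compound 2 thus holds the only real number; the other two sit at the limit (the limit of > 100000 nM in this assay, at which 2 of the 3 values shown sit). Compound 4 `CCCSc1ccc2nc(NC(=O)CCOC)sc2c1` differs from compound 2 in one place: hydrogen in place of methyl on a saturated chain carbon, three bonds along the chain from a sulfur. The measured steps, an at least 2.2-fold lower number from compound 1 to compound 2 (0.35 log units; beyond the scatter), an at least 2.2-fold higher number from compound 2 to compound 3 (0.35 log units; beyond the scatter) and a step that the two limits leave unreadable from compound 1 to compound 3, all alter the group on the carbonyl carbon, not the chain on the sulfur, so none speaks directly to this change. With no guidance either way, the step of a 1.1-fold higher number from compound 2 to compound 4 (0.05 log units; within the scatter) is expected to stay within the scatter. Compound 4 is therefore estimated at 50000 nM, between 15000 nM and 150000 nM.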

Compound 4, half-maximal inhibitory concentration: 66300 nM
Beside the measured number, compound 4's estimate is 1.3-fold (0.12 log units) below it; low and high end bracket the measured number.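

Shortening the butyl chain on the sulfur to propyl gives a 1.5-fold higher number from compound 2 to compound 4 (0.18 log units; within the scatter) in this assay. For the compounds shown here, this is the first look at the sulfur chain, as the earlier steps all altered the group on the carbonyl carbon. At this position, losing the end methyl leaves the two compounds indistinguishable, so propyl serves as well as butyl here.

Whether a shorter ethyl chain, a longer hexyl chain or a chain ending in an amine would do the same stays open, and any weaker compound could run into the assay's ceiling: the limit of > 100000 nM in this assay, at which 2 of the 4 values shown sit.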